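Methylamino for methoxy on the benzofuran analogue

The source may hold more compounds than are shown below. What is called first, only, known or untested is meant among the compounds shown, and "the series" means these compounds.

Compound 1 `COc1ncnc2c1c(-c1ccccc1)cn2[C@@H]1O[C@H](CO)[C@@H](O)[C@H]1O` is the phenyl-bearing reference of the series. In a functional assay on K562 cells (Homo sapiens), read by MTT assay, with a stated time of 72 h (on this read-out higher numbers stand for weaker inhibition and lower numbers for stronger inhibition), compound 1 gives only a limit of > 20000 nM. Compound 2 `CNc1ncnc2c1c(-c1ccccc1)cn2[C@@H]1O[C@H](CO)[C@@H](O)[C@H]1O` differs from compound 1 by methylamino in place of methoxy on an aromatic carbon. In this assay compound 2 also gives only a limit, > 20000 nM, so the step that the two limits leave unreadable from compound 1 to compound 2 cannot be sized; both values sit at the limit of > 20000 nM in this assay, at which 2 of the 3 values shown sit. Among the compounds with values here, compound 3 `COc1ncnc2c1c(-c1cc3ccccc3o1)cn2[C@@H]1O[C@H](CO)[C@@H](O)[C@H]1O` differs from compound 1 by 1-benzofuran-2-yl in place of phenyl on an aromatic carbon, and in this assay compound 3 gives 20900 nM, the one number so far. The step that the limit leaves unreadable from compound 1 to compound 3 is likewise unreadable. Compound 4 `CNc1ncnc2c1c(-c1cc3ccccc3o1)cn2[C@@H]1O[C@H](CO)[C@@H](O)[C@H]1O` has not been measured; it differs from compound 3 by methylamino in place of methoxy on an aromatic carbon, the same change as from compound 1 to compound 2. The expected step of a 1.1-fold higher number from compound 3 to compound 4 (0.02 log units; within the scatter) is small, resting on the unreadable step that the two limits leave unreadable from compound 1 to compound 2 and on the weak value that compound 3 gives, 20900 nM. Compound 4 is estimated at 22000 nM, between 8000 nM and 60000 nM, with a limit likely.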

Compound 4, half-maximal inhibitory concentration: > 20000 nM
Compound 4: no number, only a limit (the forecaster's own chance of this, stated with the estimate: 65%); the middle value is on the limit's open side.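

Compound 4 gives only a limit in this assay, so no step from compound 2 or compound 3 to compound 4 can be read: the limit of > 20000 nM in this assay, at which 3 of the 4 values shown sit.

As far as these compounds go, whether methylamino in place of methoxy or 1-benzofuran-2-yl in place of phenyl changes the value at all remains open.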